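The source may report more compounds than this note shows. Statements on the series, on what has been measured and on what is new or still open speak of the compounds shown alone.

Compound 3 `C[C@H](NC(=O)N1CCC2(CC1)C(=O)N(c1cccc(F)c1)C2c1ccc(Cl)cc1)c1ccccc1` gives 139 nM in an assay on HEK293 cells for inhibition of Voltage-dependent T-type calcium channel subunit alpha-1H (Homo sapiens), read by patch clamp, using a membrane potential dye (on this read-out higher numbers stand for weaker inhibition and lower numbers for stronger inhibition), the second highest of the three numbers. Compound 1 `CC[C@H](C)[C@H](NC(=O)N1CCC2(CC1)C(=O)N(c1cccc(F)c1)C2c1ccc(Cl)cc1)C(=O)OC(C)C` gives 45 nM, and compound 2 `COC(=O)[C@H](C)NC(=O)N1CCC2(CC1)C(=O)N(c1cccc(F)c1)C2c1ccc(Cl)cc1` gives 827 nM. Compound 4 `CCC(C)NC(=O)N1CCC2(CC1)C(=O)N(c1cccc(F)c1)C2c1ccc(Cl)cc1` differs from compound 3 by sec-butyl in place of 1-phenylethyl on an amide-type nitrogen. Going by the values given here, two measured steps bear on a smaller group on this nitrogen: a 3.1-fold higher number from compound 1 to compound 3 (0.49 log units; beyond the scatter), and the larger 18-fold higher number from compound 1 to compound 2 (1.26 log units; beyond the scatter), where the group shrank further. The step of a 5.9-fold lower number from compound 2 to compound 3 (0.77 log units; beyond the scatter) shows that phenyl here carries more than methoxycarbonyl, so its loss in compound 4 is expected to weaken inhibition. Compound 4 is therefore expected to show a 3.0-fold higher number from compound 3 to compound 4 (0.48 log units; beyond the scatter), landing near 420 nM, within the range 150 nM to 1200 nM.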

Compound 4, half-maximal inhibitory concentration: 1250 nM
Compound 4: the middle estimate sits 3.0-fold (0.47 log units) below what was measured, outside the stated range (above it).
By their numbers in this assay, from the lowest: compound 1; then compound 3; then compounds 2 and 4 (each within the scatter of the next).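

Going by these compounds alone, replacing 1-phenylethyl with sec-butyl on this amide-type nitrogen gives a 9.0-fold higher number from compound 3 to compound 4 (0.95 log units; beyond the scatter), so the loss of the aromatic ring matters more here than the earlier compounds indicated. The step of a 1.5-fold higher number from compound 2 to compound 4 (0.18 log units; within the scatter) leaves sec-butyl and 1-(methoxycarbonyl)ethyl indistinguishable at this position. The step of a 28-fold higher number from compound 1 to compound 4 (1.44 log units; beyond the scatter) shows that sec-butyl falls far short of the larger ester-bearing group of compound 1. The compounds shown leave open whether a benzyl group or a cyclohexyl ring on this nitrogen would match 1-phenylethyl. No measurement shown here explains these steps.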